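Halogen swap on the aryl ring of the enone series

A few compounds are considered here, and "the series" means these few. Any claim that something is new, unique, unknown or untested is made for them only; others in the source may bear on it.

In a functional assay on HeLa cells (Homo sapiens) for inhibition, read by sulforhodamine B assay, with a stated time of 48 h (a higher number here means a weaker inhibitor of growth, a lower number a stronger inhibitor of growth), compound 1 `CC(=O)OC/C(=C\c1ccccc1)C(=O)c1ccccc1` gives 20000 nM, compound 2 `C=C(C/C(=C\c1ccccc1)C(=O)c1ccccc1)C(=O)c1ccccc1` gives 19000 nM and compound 3 `C=C(C/C(=C\c1ccc(Cl)cc1)C(=O)c1ccccc1)C(=O)c1ccccc1` gives 22000 nM; compound 3 sits within the scatter of both compound 1 and compound 2. Among the compounds with values here, the one measured step on this ring, a 1.2-fold higher number from compound 2 to compound 3 (0.06 log units; within the scatter), is the only step that bears on the change to compound 4 `C=C(C/C(=C\c1ccc(F)cc1)C(=O)c1ccccc1)C(=O)c1ccccc1`, which is fluoro in place of chloro on an aromatic carbon. Since chloro in place of hydrogen moved nothing beyond the scatter, fluoro in place of chloro is not expected to move this assay beyond the scatter either, so the expected step is a 1.1-fold lower number from compound 3 to compound 4 (0.04 log units; within the scatter). Compound 4 is therefore estimated at 20000 nM, with a range from 10000 nM to 40000 nM.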

Compound 4, concentration for 50% growth inhibition: 18000 nM
The estimate for compound 4 lay 1.1-fold (0.05 log units) above the measured number; the range from low to high includes it.
By their numbers in this assay, from the lowest: compounds 4, 2, 1 and 3 (each within the scatter of the next).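

Fluoro in place of chloro on this aromatic carbon gives a 1.2-fold lower number from compound 3 to compound 4 (0.09 log units; within the scatter), and fluoro in place of hydrogen gives a 1.1-fold lower number from compound 2 to compound 4 (0.02 log units; within the scatter). Hydrogen, chloro and fluoro at this place therefore all lie within the scatter of one another in this assay, so swapping 4-chlorophenyl for 4-fluorophenyl does not separate the two halogens. No evidence at hand bears on this result.

On these data alone, whether an amine, a carboxylic acid or a longer chain at this place would move the number beyond the scatter remains open. Also open, as far as these compounds go, is whether fluoro or chloro elsewhere on this ring would behave the same way.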